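Working notes: nitro in place of chloro on compound 1

The source may report more compounds than this note shows. Statements on the series, on what has been measured and on what is new or still open speak of the compounds shown alone.

- Compound 1 `O=C1/C(=C/c2ccccc2Cl)Cc2ccccc21`: 57000 nM
- Compound 2 `O=C1/C(=C/c2ccccc2Br)CCCc2ccccc21`: 32100 nM
- Compound 3 `O=C1/C(=C/c2ccc(Cl)cc2Cl)Cc2ccccc21`: > 500000 nM, a limit

In a functional assay on CCRF-CEM cells (Homo sapiens) for inhibition (a lower number here means a stronger inhibitor, a higher number a weaker inhibitor), compound 1 gives 57000 nM, within the scatter of compound 2 at 32100 nM. Compound 3 reaches only the limit of > 500000 nM.

Compound 4 `O=C1/C(=C/c2ccccc2[N+](=O)[O-])Cc2ccccc21` differs from compound 1 as follows: nitro in place of chloro on an aromatic carbon. Going by the values given here, the one measured step, an at least 8.7-fold higher number from compound 1 to compound 3 (0.94 log units; beyond the scatter), adds a chloro rather than exchanging one, so it bears only loosely on this change and gives no firm direction. The expected step is therefore a 1.1-fold lower number from compound 1 to compound 4 (0.06 log units; within the scatter), with none expected beyond the scatter. Compound 4 is estimated at 50000 nM, with an expected range of 12000 nM to 200000 nM.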

Compound 4, half-maximal inhibitory concentration: 3530 nM
For compound 4 the middle estimate is 14-fold (1.15 log units) above the measured one; measured number below the stated range.
By their numbers in this assay, from the lowest: compound 4; then compounds 2 and 1 (each within the scatter of the next). At a limit, above all of these: compound 3.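

On an aromatic carbon ortho to a large group, the group present matters strongly in this assay: nitro in place of chloro gives a 16-fold lower number from compound 1 to compound 4 (1.21 log units; beyond the scatter). Going by these compounds alone, the earlier step on compound 1 added a chloro and went toward a higher number, so this exchange is the first step toward a lower one. Nothing shown gives a cause for this step.

On these data alone, whether an amine or a carboxylic acid on the same aromatic carbon would follow nitro remains open. Also open, as far as these compounds go, is whether nitro in place of bromo would give a similar step on compound 2.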